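Sulfur pentafluoride to trifluoromethyl on a sulfone core

This account rests on a few compounds, and the source may have more. Where it says the series, first, only, none or still open, it means among the compounds named here.

Compound 1 `O=C(Nc1cccc(S(F)(F)(F)(F)F)c1)c1ccc(Sc2ccc(O)cc2)cc1` gives 2940 nM in a functional assay on CWR22R cells (Homo sapiens) for antiproliferative activity, read by fluorescence and propidium iodide staining, with a stated time of 96 h; on this read-out higher numbers stand for weaker inhibition and lower numbers for stronger inhibition.
Compound 2 `O=C(Nc1cccc(C(F)(F)F)c1)c1ccc(Sc2ccc(O)cc2)cc1` gives 5730 nM in this assay.
Compound 3 `O=C(Nc1ccc(S(F)(F)(F)(F)F)cc1)c1ccc(S(=O)(=O)c2ccc(O)cc2)cc1` gives 5780 nM in this assay.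

From compound 1 to compound 2 the change is a group of 4 heavy atoms (1 carbon, 3 fluorine; no ring) in place of a group of 6 heavy atoms (5 fluorine, 1 sulfur; no ring), on an aromatic carbon, and it gave a 1.9-fold higher number from compound 1 to compound 2 (0.29 log units; within the scatter). The difference between the core of compound 1 and the core of compound 3 is not broken down here. Compound 4 `O=C(Nc1ccc(C(F)(F)F)cc1)c1ccc(S(=O)(=O)c2ccc(O)cc2)cc1` is not yet measured; from compound 3 to compound 4 the change is a group of 4 heavy atoms (1 carbon, 3 fluorine; no ring) in place of a group of 6 heavy atoms (5 fluorine, 1 sulfur; no ring), on an aromatic carbon. This is the same kind of change as that from compound 1 to compound 2, but the new group sits para to a large group in compound 4 and meta to a large group in compound 2. Because compound 1 to compound 2 gave a 1.9-fold higher number from compound 1 to compound 2 (0.29 log units; within the scatter), the step from compound 3 to compound 4 in this assay is expected to be about a 1.6-fold higher number from compound 3 to compound 4 (0.22 log units; within the scatter). Compound 4 is therefore estimated at 9500 nM, between 4000 nM and 22000 nM.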

Compound 4, half-maximal inhibitory concentration: 16800 nM
Beside the measured number, compound 4's estimate is 1.8-fold (0.25 log units) below it; low and high end bracket the measured number.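

Exchanging sulfur pentafluoride for trifluoromethyl on the core of compound 3 gave a 2.9-fold higher number from compound 3 to compound 4 (0.46 log units; beyond the scatter) in this assay. Set beside the earlier case of this exchange, the new step does not stand apart: the same change on two cores in this assay, a 1.9-fold higher number (0.29 log units; within the scatter) from compound 1 to compound 2 and a 2.9-fold higher number (0.46 log units; beyond the scatter) from compound 3 to compound 4, 1.5-fold (0.17 log units) apart, within the scatter of two such steps. This is consistent with the change carrying over between these two cores, but it rests on two pairs only, just one of the two steps lies beyond the scatter, and it does not show that the step would hold on any other core.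

The compounds shown leave open how the exchange behaves on further cores. They also leave open how a nitrile or an amine on that aromatic carbon would read in this assay.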